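This account rests on a few compounds, and the source may have more. Where it says the series, first, only, none or still open, it means among the compounds named here.

Compound 1 `C[C@H](Oc1ccc(S(C)(=O)=O)cc1C(=O)N1Cc2ccc(N3CCN(C)CC3)cc2C1)C(F)(F)F`: 490 ug/mL
Compound 2 `Cc1cccc2c1CN(C(=O)c1cc(S(C)(=O)=O)ccc1O[C@@H](C)C(F)(F)F)C2`: 73 ug/mL
Compound 3 `C[C@H](Oc1ccc(S(C)(=O)=O)cc1C(=O)N1Cc2cc(C(F)(F)F)cnc2C1)C(F)(F)F`: 280 ug/mL

In a physicochemical assay for solubility (on this read-out lower numbers stand for lower solubility and higher numbers for higher solubility), compound 1 gives 490 ug/mL, and compound 3 gives 280 ug/mL. These two values lie within the usual scatter of each other, so they share the top of this small set. Compound 2, at 73 ug/mL, lies lower than compound 1 by more than the scatter.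

The next compound to be tested is compound 4 `C[C@H](Oc1ccc(S(C)(=O)=O)cc1C(=O)N1Cc2ccc(C3CCOCC3)cc2C1)C(F)(F)F`. It keeps the core of compound 1, but oxan-4-yl stands in place of 4-methylpiperazin-1-yl on an aromatic carbon (oxan-4-yl in place of 4-methylpiperazin-1-yl on an aromatic carbon).

For the measured compounds named here, no measured pair isolates this change, so the expectation for this assay rests on loose guides. Compound 2 and compound 3 both lack the 4-methylpiperazin-1-yl group, but they also differ from compound 1 in other ways. Compound 2 at 73 ug/mL points to a clear fall, while compound 3 at 280 ug/mL goes against that reading and keeps the range wide.

The expected change is a 4.1-fold lower number from compound 1 to compound 4 (0.61 log units; beyond the scatter), an estimated fall beyond the scatter. For compound 4 the estimated value is 120 ug/mL, with an expected range from 40 ug/mL to 320 ug/mL.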

Compound 4, solubility: 76 ug/mL
Compound 4: the middle estimate sits 1.6-fold (0.20 log units) above what was measured; low and high end bracket the measured number.
By their numbers in this assay, from the lowest: compounds 2 and 4 (each within the scatter of the next); then compounds 3 and 1 (each within the scatter of the next).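

In this assay, placing oxan-4-yl instead of 4-methylpiperazin-1-yl on this aromatic carbon gives a 6.4-fold lower number from compound 1 to compound 4 (0.81 log units; beyond the scatter), a fall beyond the usual scatter. For the compounds shown here, this is the first pair in the set that differs in one place only, so the fall can be tied to this exchange of one six-membered non-aromatic ring for another, with the rest of the molecule held constant. No measurement shown explains why the number falls, and this one step cannot separate the different features of the exchanged rings.

Still open, on these data alone, is how this assay would read with other groups on this same aromatic carbon, such as morpholin-4-yl, piperidin-4-yl or an open-chain dimethylamino group, any of which could help show which part of 4-methylpiperazin-1-yl goes with the higher number. Going by these compounds alone, also open is whether the same exchange would give a step of similar size on a different core, since this pair offers only one example of it.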